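The source may report more compounds than this note shows. Statements on the series, on what has been measured and on what is new or still open speak of the compounds shown alone.

Measured in a functional assay on A549 cells (Homo sapiens) for inhibition, read by sulforhodamine B assay; a lower number here means a stronger inhibitor of growth, a higher number a weaker inhibitor of growth:
- Compound 1 `Cc1ccc2[nH]c(-c3ccc(-c4ccc(-c5cccc(Cl)c5)cc4)cc3)nc2c1`: 2800 nM
- Compound 2 `COc1ccc(-c2ccc(-c3ccc(-c4nc5cc(C)ccc5[nH]4)cc3)cc2)cc1OC`: 2100 nM

Compound 2, at 2100 nM, cannot be told apart from compound 1, at 2800 nM, as the two values lie within the scatter of each other. Compound 3 `Cc1ccc2[nH]c(-c3ccc(-c4ccc(-c5ccccc5)cc4)cc3)nc2c1` has not yet been measured. It carries phenyl in place of 3,4-dimethoxyphenyl on an aromatic carbon, para to a large group (phenyl in place of 3,4-dimethoxyphenyl on an aromatic carbon).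

Among the measured compounds shown here, only one measured step bears on this change, and it exchanges one substituted phenyl for another at the same place: a 1.3-fold lower number from compound 1 to compound 2 (0.12 log units; within the scatter). No measured compound carries phenyl itself, so this evidence is thin, but it gives no reason to expect a change beyond the scatter. The expected step is a 1.2-fold higher number from compound 2 to compound 3 (0.08 log units; within the scatter). For compound 3 the estimate is 2500 nM, with an expected range from 1000 nM to 6000 nM.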

Compound 3, concentration for 50% growth inhibition: 3630 nM
Compound 3: the middle estimate sits 1.5-fold (0.16 log units) below what was measured; the range from low to high includes it.
By their numbers in this assay, from the lowest: compounds 2, 1 and 3 (each within the scatter of the next).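

With plain phenyl at this place, this assay gives a reading for the ring with no substituent, which the two substituted rings could not supply. Against the 3,4-dimethoxyphenyl the step is small (a 1.7-fold higher number from compound 2 to compound 3 (0.24 log units; within the scatter)), and against the 3-chlorophenyl, with hydrogen in place of chloro, it is small as well (a 1.3-fold higher number from compound 1 to compound 3 (0.11 log units; within the scatter)). Neither the two methoxy groups nor the chloro can therefore be separated from plain phenyl in these compounds, and all three remain within the scatter of one another. Nothing measured here offers an explanation for these readings.

The compounds shown leave open whether an amine, a carboxylic acid or a longer chain on this ring would give a step beyond the scatter. They also leave open whether a chloro or methoxy group elsewhere on the ring would read the same.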